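Moving a ring nitrogen in a sulfamate series

A few compounds are considered here, and "the series" means these few. Any claim that something is new, unique, unknown or untested is made for them only; others in the source may bear on it.

Of the compounds shown here, three of one family have been measured in an assay on HEK293 cells for inhibition of Steryl-sulfatase (Homo sapiens), tested at 0.1 uM; on this read-out higher numbers stand for a stronger effect at the one concentration tested and lower numbers for a weaker effect. Compound 1 `CCN(Cc1ccccc1)Cc1ccc(CN2CCc3ccc(OS(N)(=O)=O)cc3C2)cc1` gives 1%. Compound 2 `CN(C)CCCN(Cc1ccccc1)c1cccc(C(=O)N2CCc3ccc(OS(N)(=O)=O)cc3C2)c1` gives 23.8%. Compound 3 `CCN(Cc1ccncc1)c1cccc(C(=O)N2CCc3ccc(OS(N)(=O)=O)cc3C2)c1` gives 33.3%, the highest of the three numbers; compound 2 lies within the scatter of it, while compound 1 lies beyond the scatter, so compound 3 cannot be set apart from compound 2 on these numbers.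

Compound 4 `CCN(Cc1ccccn1)c1cccc(C(=O)N2CCc3ccc(OS(N)(=O)=O)cc3C2)c1` has not yet been measured. It differs from compound 3 in one place only: pyridin-2-yl in place of pyridin-4-yl on a saturated chain carbon bound to a nitrogen on an aromatic ring. The two compounds share every atom and differ only in how the ring nitrogen sits within the pyridinyl group.

Within the data shown here, no measured pair in this set shows what such a move does, so the expectation rests on compound 3 alone. Among the measured compounds shown here, with the same atoms joined differently and no comparable step to draw on, the writer expects no change beyond the scatter, and estimates a number 3.3 percentage points lower from compound 3 to compound 4 (within the scatter) in this assay. Compound 4 is therefore estimated at 30%, within a range from 10% to 55%.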

Compound 4, a percentage reported as inhibition, at one concentration (the size of the read-out at that concentration, not a potency): 6.5%
Compound 4: middle estimate off by 23.5 percentage points, on the high side; the measured number lies below the stated range.
By their numbers in this assay, from the lowest: compounds 1 and 4 (each within the scatter of the next); then compounds 2 and 3 (each within the scatter of the next).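

Placing the ring nitrogen differently gives a number 26.8 percentage points lower from compound 3 to compound 4 (beyond the scatter) in this assay, so pyridin-2-yl in place of pyridin-4-yl on a saturated chain carbon bound to a nitrogen on an aromatic ring is not a neutral swap, even though no atom is gained or lost. Among these compounds, the earlier compounds offered no pair differing in one place, and this step is the first to show that the way the same atoms are joined within this group alone can move the read-out beyond the scatter. Nothing given here explains this step.

As far as these compounds go, whether pyridin-3-yl or a plain phenyl at this place would stand nearer compound 3 or compound 4 stays open. So does whether the step would hold with a propyl group in place of the ethyl on the same nitrogen.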